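From (4-methylquinazolin-2-yl)methyl to 4-methylbenzyl on a shared core

This account rests on a few compounds, and the source may have more. Where it says the series, first, only, none or still open, it means among the compounds named here.

Measured in a functional assay on PC-9 cells (Homo sapiens) for inhibition, read by MTT assay, with a stated time of 72 h; a higher number here means a weaker inhibitor, a lower number a stronger inhibitor:
- compound 1 `Cc1cc(Nc2ccn(Cc3cccc4ccccc34)n2)n2nc(SCc3ccc(Br)cc3)nc2n1` gives 5660 nM
- compound 2 `Cc1cc(Nc2ccn(Cc3ccc(F)cc3)n2)n2nc(SCc3ccc(Br)cc3)nc2n1` gives 19400 nM
- compound 3 `Cc1cc(Nc2ccn(Cc3nc(C)c4ccccc4n3)n2)n2nc(SCc3ccc(Br)cc3)nc2n1` gives 5450 nM

Compound 3 shares the low end of these numbers with compound 1, and the two are not separated (a 1.0-fold lower number from compound 1 to compound 3 (0.02 log units; within the scatter)). Compound 2 stands clearly apart from compound 3 (a 3.6-fold lower number from compound 2 to compound 3 (0.55 log units; beyond the scatter)).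

The unmeasured compound 4 `Cc1ccc(Cn2ccc(Nc3cc(C)nc4nc(SCc5ccc(Br)cc5)nn34)n2)cc1` keeps the shared core and carries 4-methylphenyl in place of 4-methylquinazolin-2-yl on a saturated chain carbon bound to an aromatic nitrogen.

Going by the values given here, the nearest precedent is compound 2, which has 4-fluorophenyl at that place. The same modest size appears in a second step (a 3.4-fold higher number from compound 1 to compound 2 (0.53 log units; beyond the scatter)). Among these three compounds, none goes against this trend, but it rests on compound 2 alone, and no measured compound carries 4-methylphenyl. A modest rise in this assay is therefore expected, perhaps somewhat smaller than those steps.

The expected change is a 2.6-fold higher number from compound 3 to compound 4 (0.41 log units; beyond the scatter) in the estimate given here.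

For compound 4 the estimated value is 14000 nM, with an expected range from 6000 nM to 30000 nM in this assay.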

Compound 4, half-maximal inhibitory concentration: > 50000 nM
Compound 4: a limit, no number; the forecaster's own chance of this, stated with the estimate: 8%; at least 3.5-fold (0.55 log units) between middle value and limit.
By their numbers in this assay, from the lowest: compounds 3 and 1 (each within the scatter of the next); then compound 2. At a limit, above all of these: compound 4.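

In this assay compound 4 gives > 50000 nM, which is a limit of the assay and not a number. Going by these compounds alone, the step of an at least 9.1-fold higher number from compound 3 to compound 4 (0.96 log units; beyond the scatter) and the step of an at least 8.8-fold higher number from compound 1 to compound 4 (0.94 log units; beyond the scatter) both go well past what the earlier compounds showed at this place, on a saturated chain carbon bound to an aromatic nitrogen. The step of an at least 2.5-fold higher number from compound 2 to compound 4 (0.41 log units; beyond the scatter) adds something new: methyl in place of fluoro on an aromatic carbon is enough to move the number, so the group on this one carbon-only ring counts as well as the choice of ring system.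

The limit leaves the true size of all three steps open. As far as these compounds go, whether a methoxy or a chloro group at that aromatic carbon, or a plain benzyl with no group there, would sit nearer compound 2 or compound 4 also stays open.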